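The source may report more compounds than this note shows. Statements on the series, on what has been measured and on what is new or still open speak of the compounds shown alone.

Series notes. Compound 1 `C=CCn1c(SCC(=O)Nc2ccc(/C(C)=N/O)cc2)nnc1-c1ccc(OC)cc1` gives 63% in a functional assay on the whole organism (strain albino) for inhibition, with Rattus norvegicus as the target, read by paw edema, with stated times of 30 min and 3 h, at a dose of 0.28 mmol/kg by the oral route; a lower number here means less inhibition, a higher number more inhibition at the dose given (going by the name of the read-out). Compound 2 `C=CCn1c(SCC(=O)Nc2ccc(C(C)=O)cc2)nnc1-c1ccc(OC)cc1` gives 52% in this assay; the step of a number 11 percentage points lower from compound 1 to compound 2 (beyond the scatter) goes with the change (a group of 3 heavy atoms (2 carbon, 1 oxygen; no ring) in place of a group of 4 heavy atoms (2 carbon, 1 nitrogen, 1 oxygen; no ring), on an aromatic carbon). Compound 3 `CCn1c(SCC(=O)Nc2ccc(/C(C)=N/O)cc2)nnc1-c1ccccc1` sits on a different core and gives 65% in this assay; its value and that of compound 1 lie within the scatter of each other, and the difference between the two cores is not broken down here. Compound 4 `CCn1c(SCC(=O)Nc2ccc(C(C)=O)cc2)nnc1-c1ccccc1` is not yet measured; it differs from compound 3 by a group of 3 heavy atoms (2 carbon, 1 oxygen; no ring) in place of a group of 4 heavy atoms (2 carbon, 1 nitrogen, 1 oxygen; no ring), on an aromatic carbon, the same change made between compound 1 and compound 2, occurring twice in all among these compounds. For compound 4 a step of similar size is expected, a number 11 percentage points lower from compound 3 to compound 4 (beyond the scatter), because a number 11 percentage points lower from compound 1 to compound 2 (beyond the scatter) was modest and beyond the scatter. Compound 4 is estimated at 54% in this assay, within a range from 44% to 64%.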

Compound 4, a percentage reported as inhibition, in the whole organism at one dose (the size of the read-out at that dose, not a potency): 56%
The estimate for compound 4 lay 2 percentage points below the measured number; the measured number falls inside the stated range.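

In this assay, acetyl on the aromatic carbon gives a number 9 percentage points lower from compound 3 to compound 4 (within the scatter), and the two steps for this change agree: the same change on two cores in this assay, a number 11 percentage points lower (beyond the scatter) from compound 1 to compound 2 and a number 9 percentage points lower (within the scatter) from compound 3 to compound 4, 2 percentage points apart, within the scatter of two such steps. The size of the step therefore shows no detectable dependence on which of these two cores carries the change. This does not establish the step on the core of compound 3 taken alone, as that step stays within the scatter, and two cores tested at a single dose say nothing about other cores or about potency.

The compounds shown leave open how an amine or a carboxylic acid on the same aromatic carbon would read. From the compounds shown here alone, whether a longer chain in place of acetyl would fit the same picture also remains open.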